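The source may report more compounds than this note shows. Statements on the series, on what has been measured and on what is new or still open speak of the compounds shown alone.

Three thioureas built on one shared core have been measured. Compound 1 `COc1ccccc1NC(=S)NC1CC(C)(C)Oc2ccc(Br)cc21` gives 22000 nM in a functional assay on U-373MG ATCC cells (Homo sapiens) for inhibition, read by MTT assay, with a stated time of 72 h; a lower number here means a stronger inhibitor, a higher number a weaker inhibitor. Compound 2 `CC1(C)CC(NC(=S)Nc2ccc([N+](=O)[O-])cc2)c2cc(Br)ccc2O1` gives 9000 nM in this assay, the lowest of the three numbers. Compound 3 `CC1(C)CC(NC(=S)Nc2ccccc2Cl)c2cc(Br)ccc2O1` gives 34000 nM in this assay, the highest of the three; it sits within the scatter of compound 1 and beyond the scatter from compound 2. Among the measured compounds shown here, the only step between close neighbours, a 1.5-fold higher number from compound 1 to compound 3 (0.19 log units; within the scatter), shows that exchanging one group for another at the same place changed little. Compound 4 `CC1(C)CC(NC(=S)Nc2ccc(Cl)cc2)c2cc(Br)ccc2O1` differs from compound 3 by 4-chlorophenyl in place of 2-chlorophenyl on an amide-type nitrogen. For the measured compounds named here, no measured step rearranges a group in this way, so the expected step of a 1.5-fold lower number from compound 3 to compound 4 (0.19 log units; within the scatter) is small, with a wide margin. Compound 4 is estimated at 22000 nM, between 8000 nM and 55000 nM.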

Compound 4, half-maximal inhibitory concentration: 7000 nM
Compound 4: the middle estimate sits 3.1-fold (0.50 log units) above what was measured, and the stated range ends above it.
By their numbers in this assay, from the lowest: compounds 4 and 2 (each within the scatter of the next); then compounds 1 and 3 (each within the scatter of the next).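

Moving the chlorine alone matters here: 4-chlorophenyl in place of 2-chlorophenyl on the amide-type nitrogen gives a 4.9-fold lower number from compound 3 to compound 4 (0.69 log units; beyond the scatter) in this assay with no atom gained or lost. 4-Chlorophenyl in place of 2-methoxyphenyl gives a similar picture, a 3.1-fold lower number from compound 1 to compound 4 (0.50 log units; beyond the scatter) at the same nitrogen. Chloro in place of nitro on an aromatic carbon gives a 1.3-fold lower number from compound 2 to compound 4 (0.11 log units; within the scatter) and so separates nothing. From the compounds shown here alone, whether an amine or a carboxylic acid in place of that chloro would hold this number stays open. No measurement shown explains why the place of the chlorine counts.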